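The compounds below may be only part of what the source reports. "The series", "measured", "known", "first", "only" and "open" are said of these compounds alone.

Measured so far in a physicochemical assay for lipophilicity; a lower number here means a more polar compound, a higher number a more lipophilic compound:
- compound 1 `Cc1cccc(C2=NC(c3ccccc3)CO2)c1`: 4.11
- compound 2 `Fc1ccccc1C1=NC(c2ccccc2)CO1`: 3.51

Lipophilicity describes how readily a compound favours a greasy environment over water, and here only two measurements are available. Compound 2 has the lower number of the pair at 3.51, while compound 1 stands higher at 4.11, and that gap lies beyond the usual scatter of repeated measurements. Within the data shown here, no two measured compounds differ in just one place, so no single change has yet been measured directly.

The next compound to be measured is compound 3 `Clc1ccccc1C1=NC(c2ccccc2)CO1`. It keeps the core of compound 2 and makes one swap: chloro in place of fluoro on an aromatic carbon. In words, this is chloro in place of fluoro on an aromatic carbon, ortho to a large group.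

Among the measured compounds shown here, with no measured step to guide it, the expectation rests on the swap itself, starting from compound 2 at 3.51. A rise in this assay is expected, modest in size but probably beyond the scatter. The estimated change is a number 0.44 log units higher from compound 2 to compound 3 (beyond the scatter). For compound 3 the expected value is 3.95, with an estimated range from 3.65 to 4.3.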

Compound 3, partition coefficient: 3.56
Estimate against measurement, compound 3: 0.39 log units above; the measured number lies below the stated range.
By their numbers in this assay, from the lowest: compounds 2 and 3 (each within the scatter of the next); then compound 1.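

Among these compounds, this is the first single change in the set whose size has been measured directly: putting chloro in place of fluoro on an aromatic carbon, ortho to a large group, gives a number 0.05 log units higher from compound 2 to compound 3 (within the scatter) in this assay. At this position, on this core, the two groups therefore cannot be told apart in this measurement, so either can stand in for the other here without a detectable difference in the read-out. Nothing available explains why the two numbers lie so close together.

This single pair cannot show whether chloro and fluoro would also be indistinguishable on another aromatic carbon of the core, or on a different core. It also leaves open how far the number would move with a quite different group at this same position, such as a methoxy group, an amine or a carboxylic acid, and whether any such swap would carry a step beyond the scatter.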